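Working notes: solubility from compound 2 to compound 4

The compounds below may be only part of what the source reports. "The series", "measured", "known", "first", "only" and "open" are said of these compounds alone.

Measured in a physicochemical assay for solubility, using the shake flask method, in phosphate buffer, with a stated time of 20 h, at pH 6.5; on this read-out lower numbers stand for lower solubility and higher numbers for higher solubility:
- compound 1 `C[S+]([O-])c1ccc(-c2ccc3ncc(-c4ccc([S+](C)[O-])cc4)n3n2)cc1` gives 200000 nM
- compound 2 `C[S+]([O-])c1ccc(-c2cnc3ccc(-c4ccc(S(C)(=O)=O)cc4)nn23)cc1` gives 5000 nM
- compound 3 `CCN(CC)Cc1ccc(-c2cnc3ccc(-c4cccc([S+](C)[O-])c4)nn23)c(F)c1` gives 200000 nM

Compound 2 stands lowest of the three numbers, with compound 1 and compound 3 both clearly higher. Compound 4 `C[S+]([O-])c1cccc(-c2cnc3ccc(-c4ccc(S(C)(=O)=O)cc4)nn23)c1` has the same atoms as compound 2, joined differently: a group of 9 heavy atoms (7 carbon, 1 oxygen, 1 sulfur; one six-membered aromatic ring of carbon only) in place of a group of 9 heavy atoms (7 carbon, 1 oxygen, 1 sulfur; one six-membered aromatic ring of carbon only), on an aromatic carbon, on a five-membered aromatic ring with 2 nitrogen. Among the measured compounds shown here, only one measured step bears on this, and loosely. For the measured compounds named here, the large step of a 40-fold lower number from compound 1 to compound 2 (1.60 log units; beyond the scatter) changes a different group, and no measured step makes this kind of swap. With compound 2 at the bottom at 5000 nM, a small rise in this assay is expected, with wide uncertainty. The estimated step is a 2.4-fold higher number from compound 2 to compound 4 (0.38 log units; beyond the scatter). Compound 4 is expected at 12000 nM, with an estimated range of 3000 nM to 50000 nM.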

Compound 4, solubility: < 5000 nM
Compound 4 was reported as a limit; the forecaster's own chance of this, stated with the estimate: 5%; at least 2.4-fold (0.38 log units) between middle value and limit.
By their numbers in this assay, from the lowest: compound 2; then compounds 1 and 3 (each within the scatter of the next).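

In this assay compound 4 is reported only as a limit, < 5000 nM. The step is a number no higher from compound 2 to compound 4 (the limit leaves the size open), and its size cannot be read, but it is the only swap shown on this aromatic carbon of the five-membered aromatic ring with 2 nitrogen, and this rearranged group brings no rise in the number: the limit of < 5000 nM in this assay, at which 1 of the 4 values shown sits.

Going by these compounds, the actual number for compound 4 stays open. So does the read-out with a carboxylic acid or a morpholine on the ring at this place.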